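Moving a methoxy group on a thiadiazole-linked aniline

The source may report more compounds than this note shows. Statements on the series, on what has been measured and on what is new or still open speak of the compounds shown alone.

Of the compounds shown here, two have been tested in a functional assay on the whole organism (strain albino) with Mus musculus as the target, in the maximal electroshock model, with a stated time of 0.5 h; a higher number here means that more compound is needed for the effect, a lower number that less compound is needed. Compound 1, `COc1ccc(Nc2nnc(Nc3nc(-c4ccc(Cl)cc4)cs3)s2)cc1`, gives 100 mg/kg. Compound 2, `COc1ccccc1Nc1nnc(Nc2nc(-c3ccc(Br)cc3)cs2)s1`, gives 300 mg/kg, which is the highest of the two numbers measured; compound 1 stands at a lower number by a gap beyond the usual scatter.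

Compound 3, `COc1ccc(Nc2nnc(Nc3nc(-c4ccc(Br)cc4)cs3)s2)cc1`, has not yet been measured. It differs from compound 2 in one place: 4-methoxyphenyl in place of 2-methoxyphenyl on a nitrogen on an aromatic ring. Compound 3 also carries a 4-methoxyphenyl on the nitrogen, as compound 1 does, while the rest of compound 3 matches compound 2.

Among the measured compounds shown here, no measured pair shows this exact change on its own, so the expectation rests on what the two measured numbers show. Compound 1, which carries the 4-methoxyphenyl, needs less compound than compound 2, which carries the 2-methoxyphenyl. A step toward a lower number in this assay is therefore expected for compound 3, of about the size seen between the two measured compounds, a 3.0-fold lower number from compound 2 to compound 3 (0.48 log units; beyond the scatter). Compound 3 is estimated at 100 mg/kg, within a range from 30 mg/kg to 300 mg/kg.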

Compound 3, minimum effective dose: 30 mg/kg
The estimate for compound 3 lay 3.3-fold (0.52 log units) above the measured number; the measured number falls inside the stated range.
By their numbers in this assay, from the lowest: compound 3; then compound 1; then compound 2.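

Compound 2 and compound 3 share everything but the place of the methoxy group, so this pair isolates a change that the two earlier compounds, which differ in two places, could not show alone. In this assay, 4-methoxyphenyl in place of 2-methoxyphenyl on a nitrogen on an aromatic ring gives a 10-fold lower number from compound 2 to compound 3 (1.00 log units; beyond the scatter), so where the methoxy group sits on this ring clearly affects how much compound is needed. The second pair shows that the halogen matters as well: with the 4-methoxyphenyl kept, bromo in place of chloro on an aromatic carbon gives a 3.3-fold lower number from compound 1 to compound 3 (0.52 log units; beyond the scatter), also beyond the usual scatter, and nothing available here accounts for either step.

Each step rests on a single pair, so neither can be assumed to hold on a different core or alongside a different partner group. The compounds shown leave open whether an ethoxy group or an amine at the place of the methoxy group would lower the number further, and whether fluoro or iodo at the place of the bromo would follow the step from chloro to bromo.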